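Sulfonyl substituent changes in a pyridylmethyl urea series

The source may report more compounds than this note shows. Statements on the series, on what has been measured and on what is new or still open speak of the compounds shown alone.

Measured compounds:
- compound 1 `O=C(NCc1ccncc1)Nc1ccc(S(=O)(=O)c2cccc(Cl)c2)cc1`: 69 nM
- compound 2 `NS(=O)(=O)c1ccc(NC(=O)NCc2ccncc2)cc1`: 14300 nM
- compound 3 `O=C(NCc1ccncc1)Nc1ccc(S(=O)(=O)c2ccccc2)cc1`: 85 nM

In an assay on isolated protein for activation of Nicotinamide phosphoribosyltransferase (Homo sapiens) (a higher number here means that more compound is needed for the effect, a lower number that less compound is needed), compound 3 gives 85 nM, the second highest of the three numbers. Its nearest neighbour is compound 1, differing by a 1.2-fold higher number from compound 1 to compound 3 (0.09 log units; within the scatter), a change of hydrogen in place of chloro on an aromatic carbon. Its furthest is compound 2, reached by a 170-fold lower number from compound 2 to compound 3 (2.23 log units; beyond the scatter), phenyl in place of amino on a sulfonyl sulfur.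

Compound 4 `CN(C)S(=O)(=O)c1ccc(NC(=O)NCc2ccncc2)cc1` is not yet measured. It differs from compound 3 by dimethylamino in place of phenyl on a sulfonyl sulfur. Going by the values given here, the steps that bear on this change are the two that alter the group on the sulfonyl sulfur: a 210-fold higher number from compound 1 to compound 2 (2.32 log units; beyond the scatter) and a 170-fold lower number from compound 2 to compound 3 (2.23 log units; beyond the scatter), both large, both showing that an amino group on the sulfonyl sulfur goes with a much higher number than a phenyl. Dimethylamino, with no ring and three heavy atoms, stands closer to amino than to phenyl in that count, so a large upward step in this assay is expected, though the two methyl groups make the full span of a 170-fold lower number from compound 2 to compound 3 (2.23 log units; beyond the scatter) uncertain.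

Compound 4 is therefore estimated at 3000 nM, with a range from 600 nM to 15000 nM, which means an expected step of a 35-fold higher number from compound 3 to compound 4 (1.55 log units; beyond the scatter).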

Compound 4, half-maximal effective concentration: 3110 nM
Estimate against measurement, compound 4: 1.0-fold (0.02 log units) below; the measured number falls inside the stated range.
By their numbers in this assay, from the lowest: compounds 1 and 3 (each within the scatter of the next); then compound 4; then compound 2.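

Notes on the group on the sulfonyl sulfur: in this assay, dimethylamino shows that a group with no ring can be separated from both aryl sulfones, with a 37-fold higher number from compound 3 to compound 4 (1.56 log units; beyond the scatter) and a 45-fold higher number from compound 1 to compound 4 (1.65 log units; beyond the scatter). The groups without a ring do not form one level, since the comparison with amino gives a 4.6-fold lower number from compound 2 to compound 4 (0.66 log units; beyond the scatter), a modest step that is much smaller than either step from the aryl groups. No measurement here gives a reason for these steps.

From the compounds shown here alone, it remains open whether a piperidine ring on the sulfonyl sulfur would fall with compound 3 or with compound 4. A cyclohexyl group would put the same question to a carbon ring that is not aromatic, while a diethylamino group would test whether longer chains on the nitrogen extend the step seen with dimethylamino.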